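Capping the Ring Nitrogen: From a Limit Toward Activity

The source may hold more compounds than are shown below. What is called first, only, known or untested is meant among the compounds shown, and "the series" means these compounds.

Compound 1 `O=C1NC(c2ccccc2)CN1S(=O)(=O)c1ccc2c(c1)CCCN2` is the starting point. In a functional assay on A549 cells (Homo sapiens) for antiproliferative activity, read by MTT assay (a higher number here means a weaker inhibitor, a lower number a stronger inhibitor), compound 1 reaches only the limit of the assay, > 20000 nM, so it stands at the weak end of the numbers shown, known merely as a bound (the limit of > 20000 nM in this assay, at which 1 of the 3 values shown sits). Compound 2 `CCCOC(=O)N1CCCc2cc(S(=O)(=O)N3CC(c4ccccc4)NC3=O)ccc21` keeps the shared core but caps the nitrogen on the aromatic ring in a ring, and in this assay compound 2 gives 1030 nM. Within the data shown here, the resulting step, an at least 19-fold lower number from compound 1 to compound 2 (1.28 log units; beyond the scatter), is the only measured step that bears on the change considered here, and it is large. Compound 3 `O=C(CCl)N1CCCc2cc(S(=O)(=O)N3CC(c4ccccc4)NC3=O)ccc21` caps the same nitrogen differently, yet in this assay compound 3 has "not determined" (no result reported). Compound 4 `O=C(CCl)NC(=O)N1CCCc2cc(S(=O)(=O)N3CC(c4ccccc4)NC3=O)ccc21` differs from compound 1 as follows: ((chloromethyl)carbonyl)carbamoyl in place of hydrogen on a nitrogen on an aromatic ring in a ring. Because the one known capping of that nitrogen produced an at least 19-fold lower number from compound 1 to compound 2 (1.28 log units; beyond the scatter), a step of similar size and direction is expected here, though its exact extent is uncertain. Compound 4 is therefore expected to give about 1200 nM, within a range from 300 nM to 6000 nM. That estimate corresponds to an expected at least 16-fold lower number from compound 1 to compound 4 (1.22 log units; beyond the scatter).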

Compound 4, half-maximal inhibitory concentration: 449 nM
For compound 4 the middle estimate is 2.7-fold (0.43 log units) above the measured one; the range from low to high includes it.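

In this assay, a second capping group on the nitrogen on an aromatic ring in a ring also brings a large gain: an at least 44-fold lower number from compound 1 to compound 4 (1.64 log units; beyond the scatter). The gain seen with compound 2 is therefore not confined to propoxycarbonyl, and the choice of cap still counts, as ((chloromethyl)carbonyl)amino in place of propoxy on a carbonyl carbon gives a 2.3-fold lower number from compound 2 to compound 4 (0.36 log units; beyond the scatter). Compound 1 is known only as a limit, and the true size of the gain from capping stays unknown: the limit of > 20000 nM in this assay, at which 1 of the 4 values shown sits.

Steps involving compound 3 cannot be read. From the compounds shown here alone, whether the chlorine itself contributes stays open, as does what a plain acetyl group or a cap carrying an amine would do on this nitrogen.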